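The source may report more compounds than this note shows. Statements on the series, on what has been measured and on what is new or still open speak of the compounds shown alone.

Measured in a functional assay on HCT-116 cells (Homo sapiens) for cytotoxicity, read by sulforhodamine B assay; on this read-out higher numbers stand for weaker inhibition of growth and lower numbers for stronger inhibition of growth:
- Compound 1 `Nc1ncnc2c1nc(NCc1ccc(Cl)c(Cl)c1)n2[C@@H]1O[C@H](COCc2ccccc2)[C@@H](O)[C@H]1O`: > 80000 nM
- Compound 2 `Nc1ncnc2c1nc(NCc1ccc(Cl)c(Cl)c1)n2[C@@H]1O[C@H](CO)[C@@H](O)[C@H]1O`: 26000 nM
- Compound 3 `N#Cc1ccc(COC[C@H]2O[C@@H](n3c(NCc4ccc5ncccc5c4)nc4c(N)ncnc43)[C@H](O)[C@@H]2O)cc1`: > 80000 nM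

Compound 3 gives no number, only a limit, > 80000 nM. Compound 1 also gives only a limit, > 80000 nM, so the picture is dominated by the limit of > 80000 nM in this assay, at which 2 of the 3 values shown sit.

Compound 4 `N#Cc1ccc(COC[C@H]2O[C@@H](n3c(NCc4ccc(Cl)c(Cl)c4)nc4c(N)ncnc43)[C@H](O)[C@@H]2O)cc1` brings 3,4-dichlorophenyl in place of quinolin-6-yl on a saturated chain carbon bound to a nitrogen on an aromatic ring.

Among the compounds with values here, no measured step makes this change. The closest evidence is an at least 3.0-fold lower number from compound 1 to compound 2 (0.48 log units; beyond the scatter), a modest step at an oxygen that compound 4 keeps substituted, as compound 1 does. Compound 4 also shares the (3,4-dichlorobenzyl)amino group of compound 1, so it is expected to stay weak in this assay, with no clear step. The expected step is an at least 1.1-fold lower number from compound 3 to compound 4 (0.05 log units; that floor lies within the scatter). The estimate for compound 4 is 70000 nM, with an expected range of 25000 nM to 120000 nM.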

Compound 4, concentration for 50% growth inhibition: 5000 nM
The estimate for compound 4 lay 14-fold (1.15 log units) above the measured number; measured number below the stated range.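

In this assay, the group on the saturated chain carbon bound to a nitrogen on an aromatic ring matters strongly: 3,4-dichlorophenyl in place of quinolin-6-yl gives an at least 16-fold lower number from compound 3 to compound 4 (1.20 log units; beyond the scatter). A substituted oxygen need not weaken growth inhibition, since 4-cyanobenzyl in place of hydrogen gives a 5.2-fold lower number from compound 2 to compound 4 (0.72 log units; beyond the scatter). Plain benzyl on that oxygen is the weak case, and cyano in place of hydrogen on its aromatic carbon gives an at least 16-fold lower number from compound 1 to compound 4 (1.20 log units; beyond the scatter).

Going by these compounds, the true size of the two large steps stays open, since each starts from a limit: the limit of > 80000 nM in this assay, at which 2 of the 4 values shown sit. Whether an amine or a carboxylic acid could replace the cyano is also unanswered.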